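Adding a Second Chloro to the Benzyl Group

This account rests on a few compounds, and the source may have more. Where it says the series, first, only, none or still open, it means among the compounds named here.

Measured in a functional assay on HeLa cells (Homo sapiens) for antiproliferative activity, read by MTT assay, with a stated time of 48 h, in the presence of a further agent that is not named here; a lower number here means a stronger inhibitor of growth, a higher number a weaker inhibitor of growth:
compound 1 `Cc1ccc(-c2nn(-c3ccccc3)cc2C(=O)NOCc2ccccc2)cc1`: 6690 nM
compound 2 `Cc1ccc(-c2nn(-c3ccccc3)cc2C(=O)NOCc2ccccc2Cl)cc1`: 4680 nM
compound 3 `COc1ccc(-c2nn(-c3ccccc3)cc2C(=O)NOCc2ccccc2Cl)cc1`: 3480 nM

Going from compound 1 to compound 2 the change is chloro in place of hydrogen on an aromatic carbon, and in this assay it gives a 1.4-fold lower number from compound 1 to compound 2 (0.16 log units; within the scatter). From compound 2 to compound 3, with methoxy in place of methyl on an aromatic carbon, the step is a 1.3-fold lower number from compound 2 to compound 3 (0.13 log units; within the scatter). The difference between the core of compound 1 and the core of compound 3 is not broken down here. All three values lie within the scatter of one another.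

Compound 4 `COc1ccc(-c2nn(-c3ccccc3)cc2C(=O)NOCc2ccc(Cl)cc2Cl)cc1` is not yet measured. It differs from compound 3 by chloro in place of hydrogen on an aromatic carbon. Within the data shown here, this is the same kind of change as the one from compound 1 to compound 2, but the place is not the same: there the chloro entered ortho to a large group, here it enters meta to a chloro group and para to a large group. In this assay the step from compound 3 to compound 4 is expected to be a 1.2-fold lower number from compound 3 to compound 4 (0.09 log units; within the scatter) because a 1.4-fold lower number from compound 1 to compound 2 (0.16 log units; within the scatter) was small and within the scatter. Compound 4 is therefore estimated at 2800 nM, expected between 1200 nM and 7000 nM.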

Compound 4, concentration for 50% growth inhibition: 5750 nM
The estimate for compound 4 lay 2.1-fold (0.31 log units) below the measured number; low and high end bracket the measured number.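

In this assay, the added chloro that turns 2-chlorobenzyl into 2,4-dichlorobenzyl gives a 1.7-fold higher number from compound 3 to compound 4 (0.22 log units; within the scatter). Set beside the earlier chloro addition, which was made on a different core and at a different place on the benzyl group, this step cannot be told apart from it: the same change on two cores in this assay, a 1.4-fold lower number (0.16 log units; within the scatter) from compound 1 to compound 2 and a 1.7-fold higher number (0.22 log units; within the scatter) from compound 3 to compound 4, 2.4-fold (0.37 log units) apart, within the scatter of two such steps. This shows only that, in these two cases, adding a chloro to the benzyl group left the number within the usual scatter; it does not show that the change raises or lowers growth inhibition, or that it would carry a fixed effect to another core, and the effects of core and place cannot be separated here.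

The compounds shown leave open whether a different kind of group on the benzyl group, such as an amine or a carboxylic acid, would give a step beyond the scatter. On these data alone, it also remains open whether a longer chain in place of the benzyl group would do so.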